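A few compounds are considered here, and "the series" means these few. Any claim that something is new, unique, unknown or untested is made for them only; others in the source may bear on it.

For the measured compounds named here, compound 1 `Cc1c(C(=O)NCc2cccc(C(F)(F)F)c2)cnn1-c1ccc(F)cc1` gives the only plain number among the values shown: in a functional assay on cells for antagonist activity at C-C chemokine receptor type 1 (Homo sapiens), read by FLIPR and calcium flux (on this read-out higher numbers stand for weaker inhibition and lower numbers for stronger inhibition), compound 1 gives 790 nM. Compound 2 `Cc1c(C(=O)NCc2cccc(C(F)(F)F)c2)cnn1-c1cccc(C(F)(F)F)c1` carries 3-(trifluoromethyl)phenyl in place of 4-fluorophenyl on an aromatic nitrogen. In this assay compound 2 reaches only a limit of the assay, > 3000 nM. That step is an at least 3.7-fold higher number from compound 1 to compound 2 (0.57 log units; beyond the scatter), resting on (the limit of > 3000 nM in this assay, at which 1 of the 2 values shown sits). Compound 3 `Cc1c(C(=O)NCc2cccc(C(F)(F)F)c2)cnn1-c1ccc([N+](=O)[O-])cc1` differs from compound 1 by nitro in place of fluoro on an aromatic carbon, the nitro sitting on an aromatic carbon of a six-membered aromatic ring of carbon only, para to a large group. Going by the values given here, the one measured step also exchanges the group on that ring, so it bears on this change only loosely: it runs toward weaker inhibition, yet with a different group at a different place. A smaller loss is therefore expected here. Compound 3 is expected to give 1600 nM, within 500 nM to 5000 nM, which means an expected step of a 2.0-fold higher number from compound 1 to compound 3 (0.31 log units; beyond the scatter).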

Compound 3, half-maximal inhibitory concentration: 960 nM
Compound 3: middle estimate off by 1.7-fold (0.22 log units), on the high side, and the stated range covers the measured number.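

Exchanging fluoro for nitro at this place leaves the read-out in this assay essentially where it was, with a 1.2-fold higher number from compound 1 to compound 3 (0.08 log units; within the scatter), so here nitro, with 3 heavy atoms, serves as well as fluoro, with 1. The weak result of compound 2 is thus not shared by every replacement of the 4-fluorophenyl group: going from 3-(trifluoromethyl)phenyl to 4-nitrophenyl gives an at least 3.1-fold lower number from compound 2 to compound 3 (0.49 log units; beyond the scatter). That step is only a minimum, because one of its ends is a limit of the assay and not a true number: the limit of > 3000 nM in this assay, at which 1 of the 3 values shown sits.

On these data alone, whether the weakness of compound 2 goes with the trifluoromethyl group itself or with where it sits on the ring remains open. Also open, as far as these compounds go, is how an amine or a carboxylic acid in place of the fluoro would read in this assay.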